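Swapping a hydroxy for hydrogen on compound 2

The source may hold more compounds than are shown below. What is called first, only, known or untested is meant among the compounds shown, and "the series" means these compounds.

In a functional assay on COLO 205 cells (Homo sapiens) for cytotoxicity, read by MTT assay, with a stated time of 48 h (on this read-out lower numbers stand for stronger inhibition and higher numbers for weaker inhibition), two compounds have results so far. Compound 1 `C=C[C@@]1(C)COC(=O)[C@]12OC([C@H](C)CC)=CC2=O` reads > 100 ug/mL here, which is a limit of the assay and not a number. For the measured compounds named here, compound 2 `C=C[C@@]1(C)COC(=O)C1(O)C(=O)/C=C(\O)c1ccccc1` gives 79 ug/mL as the only true number, so it cannot yet be ranked against a measured neighbour.

The change hydrogen in place of hydroxy on a saturated ring carbon puts hydrogen in place of hydroxy on a saturated ring carbon of compound 2 and leads to compound 3 `C=C[C@@]1(C)COC(=O)C1C(=O)/C=C(\O)c1ccccc1` as the untested partner. Going by the values given here, no measured pair shows this swap, so no step beyond the usual scatter is expected in either direction, with compound 2 at 79 ug/mL as the only anchor. The estimated step of a 1.1-fold lower number from compound 2 to compound 3 (0.02 log units; within the scatter) stays small for that reason. Compound 3 could also end up reported only as a limit. For compound 3 the expected value is 75 ug/mL (estimated range 35 ug/mL to 140 ug/mL).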

Compound 3, half-maximal inhibitory concentration: 37.5 ug/mL
For compound 3 the middle estimate is 2.0-fold (0.30 log units) above the measured one; measured number inside the range.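

In this assay, putting hydrogen in place of hydroxy on the saturated ring carbon gives a 2.1-fold lower number from compound 2 to compound 3 (0.32 log units; beyond the scatter), a modest step but the first at this position that can be read as a real difference. This shows that the number responds to what sits on this carbon, and that the hydroxy is not required for the cytotoxicity seen with compound 2, since the partner without it reads lower, which here means stronger inhibition. Nothing available explains why the number moves in this direction.

From the compounds shown here alone, whether a different group on this carbon, such as a fluorine, a methoxy or an amine, would lower the number further or raise it again remains open. So does whether this swap would give a similar step on a different core.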